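The compounds below may be only part of what the source reports. "The series", "measured", "known", "first", "only" and "open" are said of these compounds alone.

Compound 1 `CCOC(=O)N1CCC(=NNC(=O)c2ccc(Cl)cc2)CC1`: 72300 nM
Compound 2 `CCOC(=O)N1CCC(=NNC(=O)c2ccc(C)cc2)CC1`: 52500 nM
Compound 3 `CCOC(=O)N1CCC(=NNC(=O)c2ccc(C(F)(F)F)cc2)CC1`: 49300 nM

These values come from a functional assay for inhibition, read by spectrophotometry, with a stated time of 120 min; on this read-out higher numbers stand for weaker inhibition and lower numbers for stronger inhibition. Compound 2, at 52500 nM, lies within the scatter of both compound 1 and compound 3. Compound 4 `CCOC(=O)N1CCC(=NNC(=O)c2ccc([N+](=O)[O-])cc2)CC1` has not yet been measured. It carries nitro in place of methyl on an aromatic carbon. The measured steps that bear on this change are swaps at the same place: a 1.4-fold lower number from compound 1 to compound 2 (0.14 log units; within the scatter), a 1.5-fold lower number from compound 1 to compound 3 (0.17 log units; within the scatter) and a 1.1-fold lower number from compound 2 to compound 3 (0.03 log units; within the scatter). All three stay within the scatter, although none of them involves nitro, so no step beyond the scatter is expected in this assay. The expected step is a 1.0-fold higher number from compound 2 to compound 4 (0.02 log units; within the scatter). For compound 4 the estimated value is 55000 nM, with an expected range of 28000 nM to 105000 nM.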

Compound 4, half-maximal inhibitory concentration: 40200 nM
Estimate against measurement, compound 4: 1.4-fold (0.14 log units) above; the range from low to high includes it.
By their numbers in this assay, from the lowest: compounds 4, 3, 2 and 1 (each within the scatter of the next).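

Nitro brings two hydrogen-bond acceptors where methyl has none, yet in this assay the number stays within the scatter, with a 1.3-fold lower number from compound 2 to compound 4 (0.12 log units; within the scatter) and a 1.2-fold lower number from compound 3 to compound 4 (0.09 log units; within the scatter) and a 1.8-fold lower number from compound 1 to compound 4 (0.25 log units; within the scatter). Across methyl, chloro, trifluoromethyl and nitro, this position has therefore shown no step beyond the scatter. No measurement at hand offers an explanation for this. Going by these compounds, whether an amine or a carboxylic acid at this position would move the number beyond the scatter stays open. So does the effect of any change elsewhere on the shared core.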